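What Happens When Compound 1 Loses Its Side Group

A few compounds are considered here, and "the series" means these few. Any claim that something is new, unique, unknown or untested is made for them only; others in the source may bear on it.

Measured so far in a functional assay on HeLa cells (Homo sapiens) for antiproliferative activity, read by MTT assay, with a stated time of 6 days; on this read-out lower numbers stand for stronger inhibition and higher numbers for weaker inhibition:
- compound 1 `COc1ccc(/C=C/C(=O)OC[C@@H](OCc2ccccc2)[C@H]2OC(=O)C=C[C@H]2OCc2ccccc2)cc1` gives 1080 nM
- compound 2 `O=C1C=C[C@@H](OCc2ccccc2)[C@@H]([C@@H](COC(=O)/C=C/c2ccc([N+](=O)[O-])cc2)OCc2ccccc2)O1` gives 2650 nM

Compound 1 holds the lower of these two numbers, so it is the stronger inhibitor of the pair. The next question concerns compound 3 `O=C1C=C[C@@H](OCc2ccccc2)[C@@H]([C@@H](CO)OCc2ccccc2)O1`, which keeps the core of compound 1 but differs by hydrogen in place of (2-(4-methoxyphenyl)ethenyl)carbonyl on an oxygen on a saturated carbon. Put simply, hydrogen stands in place of the whole (2-(4-methoxyphenyl)ethenyl)carbonyl group on an oxygen on a saturated carbon.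

Within the data shown here, only one measured step bears on this change. That step, a 2.5-fold higher number from compound 1 to compound 2 (0.39 log units; beyond the scatter), exchanged a methoxy group for a nitro group inside the group that compound 3 lacks. It is modest but shows that editing this group can move the number. Among the measured compounds shown here, no compound without the group has been measured, so this guide is weak. Losing the entire group is a larger edit than that swap, so a similar or somewhat larger step towards a higher number is expected in this assay. The expected change is a 3.0-fold higher number from compound 1 to compound 3 (0.47 log units; beyond the scatter) as an estimate. For compound 3 the estimated value is 3200 nM, with an expected range from 1100 nM to 9000 nM as the likely span.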

Compound 3, half-maximal inhibitory concentration: 4800 nM
Compound 3: middle estimate off by 1.5-fold (0.18 log units), on the low side, and the stated range covers the measured number.
By their numbers in this assay, from the lowest: compound 1; then compounds 2 and 3 (each within the scatter of the next).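

In this assay, taking the whole (2-(4-methoxyphenyl)ethenyl)carbonyl group off the oxygen on a saturated carbon gives a 4.4-fold higher number from compound 1 to compound 3 (0.65 log units; beyond the scatter), so the group counts for something in compound 1, yet it is not required, since compound 3, with only a hydrogen there, still gives 4800 nM. The group does not show a clear gain in every form, because the values of compound 2, which has a nitro group in place of the methoxy group, and compound 3 lie within the usual scatter of each other, so among these compounds only the methoxy form stands clearly apart from the bare hydrogen. Nothing measured here explains why the number shifts with this change.

On these data alone, it remains open which part of the group matters, and whether a plain acetyl group on this oxygen would sit closer to compound 1 or to compound 3. Also open, as far as these compounds go, is how an amine or a fluorine in place of the methoxy group on the aromatic carbon would compare with compound 1.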